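The source may hold more compounds than are shown below. What is called first, only, known or untested is meant among the compounds shown, and "the series" means these compounds.

Compound 1, `N#Cc1ccc(Oc2cccnc2)cc1F`, gives 15% in an assay on isolated protein for inhibition of Aromatase (Homo sapiens), read by fluorescence, tested at 1 uM (a higher number here means more inhibition at the concentration tested (going by the name of the read-out), a lower number less inhibition), the lowest of the three numbers measured. Compound 2, `N#Cc1ccc(Oc2cccnc2)c(Oc2cccnc2)c1`, gives 82% in this assay, and compound 3, `N#Cc1ccc(Oc2cccnc2)c(Oc2cccc(Cl)c2)c1`, gives 89%; the step of a number 7 percentage points higher from compound 2 to compound 3 (within the scatter) shows that exchanging one aromatic ring on an oxygen for another changed little. Compound 4, `N#Cc1ccc(Oc2cccnc2)cc1Oc1ccccc1`, differs from compound 1 by phenoxy in place of fluoro on an aromatic carbon. Going by the values given here, no measured step mirrors this exact change, but compound 2 and compound 3, each carrying two groups attached through oxygen, both sit far above compound 1, which carries only one. A large rise is therefore expected, with a number 60 percentage points higher from compound 1 to compound 4 (beyond the scatter). Compound 4 is estimated at 75%, between 50% and 92%.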

Compound 4, a percentage reported as inhibition, at one concentration (the size of the read-out at that concentration, not a potency): 78%
For compound 4 the middle estimate is 3 percentage points below the measured one; the range from low to high includes it.
By their numbers in this assay, from the lowest: compound 1; then compounds 4, 2 and 3 (each within the scatter of the next, the first and the last beyond it).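

In this assay, phenoxy in place of fluoro on this aromatic carbon, ortho to a cyano group, gives a number 63 percentage points higher from compound 1 to compound 4 (beyond the scatter). This single change is enough to lift a weakly inhibiting compound into the range of the two-oxygen compounds, so the position accepts a far larger group than fluoro. Nothing available explains why the number rises.

From the compounds shown here alone, it stays open whether the oxygen or the ring of the phenoxy group carries the rise. Methoxy, an amine or a chlorine on the phenoxy ring at this position would help separate these.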